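Hydrogen for Chloro on a Benzyl Amide: Cytotoxicity Outlook

The source may hold more compounds than are shown below. What is called first, only, known or untested is meant among the compounds shown, and "the series" means these compounds.

Compound 1, `CC(CSc1nnc(-c2ccncc2)s1)C(=O)Nc1ccc(Cl)cc1`: > 50000 nM
Compound 2, `CC(CSc1nnc(-c2ccncc2)s1)C(=O)NCc1ccc(Cl)cc1`: "not determined" (no result reported)

Compound 1, carrying the anilide, was run in an ADME assay on BHK-21 cells (Mesocricetus auratus) for cytotoxicity, with a stated time of 3 days; on this read-out higher numbers stand for lower toxicity in this test and lower numbers for higher toxicity in this test. In that test compound 1 gives > 50000 nM, which is a limit of the assay and not a number. Compound 2 carries a benzyl amide instead, and in this assay compound 2 gives "not determined" (no result reported), so no number stands for it at all. Compound 2 therefore has no place on the numbers shown. Of the two entries, compound 1 alone sits at the limit of > 50000 nM in this assay, at which 1 of the 2 values shown sits.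

Compound 3, `CC(CSc1nnc(-c2ccncc2)s1)C(=O)NCc1ccccc1`, differs from compound 2 in a single place: hydrogen in place of chloro on an aromatic carbon. Going by the values given here, no step between two measured compounds is available, so there is nothing against which to size this change. In the absence of any measured step, the expected change from compound 2 to compound 3 is none beyond the scatter, with no direction preferred. In this assay compound 3 is accordingly estimated at about 50000 nM, within a range from 20000 nM to 120000 nM, and the result is expected most likely to be reported as a limit rather than as a number.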

Compound 3, half-maximal cytotoxic concentration: > 50000 nM
Compound 3: only a limit was reported; the forecaster's own chance of this, stated with the estimate: 75%; the middle value sits exactly at the limit.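

In this assay compound 3 gives > 50000 nM, which is a limit of the assay and not a number. Compound 1 also stands at a limit, so no step can be read between compound 1 and compound 3. The compounds shown leave open how the cytotoxicity of compound 1 and compound 3 would compare as numbers, and what the chloro of compound 2 contributes.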